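This account rests on a few compounds, and the source may have more. Where it says the series, first, only, none or still open, it means among the compounds named here.

Compound 1, `Cc1ccccc1-n1c(Nc2nc(-c3ccc(Br)cc3)cs2)n[nH]c1=S`, gives 100 mg/kg.
Compound 2, `Cc1ccc(-n2c(Nc3nc(-c4ccccc4)cs3)n[nH]c2=S)cc1`, gives 300 mg/kg.

Both compounds were tested in a functional assay on the whole organism (strain Swiss albino) for inhibition, with Mus musculus as the target, with a stated time of 0.5 h; a higher number here means that more compound is needed for the effect, a lower number that less compound is needed. Of the two numbers shown, compound 2 stands highest: the dose that compound 2 needs, 300 mg/kg, is beyond the usual scatter away from the dose of compound 1, which is 100 mg/kg, so more of compound 2 is needed for the same effect. Compound 1 and compound 2 differ in two places at once, so their two values alone do not separate the two changes.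

The next compound, compound 3, `Cc1ccc(-n2c(Nc3nc(-c4ccc(Br)cc4)cs3)n[nH]c2=S)cc1`, differs from compound 2 in one place: bromo in place of hydrogen on an aromatic carbon. Compound 1 also carries a bromo and needs less compound, which hints that the change may lower the number, though compound 1 differs in a second place too. The step from compound 2 to compound 3 is expected to be a 2.0-fold lower number from compound 2 to compound 3 (0.30 log units; within the scatter), a moderate drop. Compound 3 is therefore estimated at 150 mg/kg, within a range of 75 mg/kg to 300 mg/kg.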

Compound 3, minimum effective dose: 300 mg/kg
The estimate for compound 3 lay 2.0-fold (0.30 log units) below the measured number; the range from low to high includes it.
By their numbers in this assay, from the lowest: compound 1; then compounds 2 and 3 (each within the scatter of the next).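

In this assay, the change from phenyl to 4-bromophenyl gives no change at the digits printed from compound 2 to compound 3 (within the scatter), so with 4-methylphenyl on the aromatic nitrogen, the bromo does not separate these two compounds. With the bromo kept, 4-methylphenyl in place of 2-methylphenyl gives a 3.0-fold higher number from compound 1 to compound 3 (0.48 log units; beyond the scatter), which places the difference between these two compounds in the methylphenyl group rather than in the bromo. Nothing available explains why the number moves with one change and stays put with the other.

On these data alone, whether the bromo would matter when the 2-methylphenyl group is present remains open, since a single pair cannot show this. Also open, as far as these compounds go, is how a chloro, an amine or a carboxylic acid at the bromo's position would affect the dose needed.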